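The source may hold more compounds than are shown below. What is called first, only, known or untested is meant among the compounds shown, and "the series" means these compounds.

Measured so far in an ADME assay on A549 cells (Homo sapiens) for cytotoxicity, read by CellTiter-Glo; on this read-out lower numbers stand for higher toxicity in this test and higher numbers for lower toxicity in this test:
compound 1 `Cc1c(Cc2ccc(OC(F)(F)F)cc2)c(=O)oc2cc(OCC(O)CN3CCC(C(N)=O)CC3)ccc12` — compound 1 gives 68200 nM
compound 2 `Cc1c(Cc2ccc(-c3ccccc3C#N)cc2)c(=O)oc2cc(OCC(O)CN3CCC(C(N)=O)CC3)ccc12` — compound 2 gives 33200 nM

Going by the values given here, compound 1 holds the higher of the two numbers in this assay; its only neighbour is reached by a 2.1-fold lower number from compound 1 to compound 2 (0.31 log units; beyond the scatter). Compound 3 `Cc1c(Cc2ccc(OC(F)(F)F)cc2)c(=O)oc2cc(OC[C@H](O)CN3CCC(C(N)=O)CC3)ccc12` differs from compound 1 in that (the two compounds have the same atoms and bonds; at least one stereo element is drawn with a configuration in one of them and without one in the other: 1 of 1 stereo elements differ; a stereocentre at a saturated chain carbon is drawn without a configuration in compound 1 and R in compound 3). Among the compounds with values here, the single measured step concerns a group exchange on an aromatic carbon and says nothing about a drawn configuration, so no measured step bears on this change. In this assay compound 3 is therefore expected to sit with compound 1, with a step of a 1.0-fold lower number from compound 1 to compound 3 (0.00 log units; within the scatter) expected, none beyond the scatter. The estimate for compound 3 is 68000 nM, range 30000 nM to 150000 nM.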

Compound 3, half-maximal cytotoxic concentration: 52000 nM
The estimate for compound 3 lay 1.3-fold (0.12 log units) above the measured number; low and high end bracket the measured number.
By their numbers in this assay, from the lowest: compounds 2, 3 and 1 (each within the scatter of the next, the first and the last beyond it).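

In this assay, setting the stereocentre at the saturated chain carbon as R gives a 1.3-fold lower number from compound 1 to compound 3 (0.12 log units; within the scatter), so the number does not separate the two drawings of this carbon. Unlike the earlier exchange on the aromatic carbon, this change leaves atoms and bonds untouched and moves the read-out by no more than the scatter. The comparison carries one limit: the fact that one of compounds 1 and 3 is drawn with a defined configuration and the other without, at the place where they differ

From the compounds shown here alone, the S configuration at this carbon remains open. So does the reading in this assay for a carboxylic acid in place of the amide.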